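This account rests on a few compounds, and the source may have more. Where it says the series, first, only, none or still open, it means among the compounds named here.

Among the compounds with values here, compound 1 `Cc1cc(Cl)ccc1NC(=O)Nc1nc(Sc2c[nH]c3ccccc23)cc(N2CCN(Cc3ccccc3)CC2)n1` is one of two compounds measured so far in a functional assay on HepG2 cells (Homo sapiens) for inhibition, with a stated time of 72 h; a higher number here means a weaker inhibitor, a lower number a stronger inhibitor. In this assay compound 1 gives 11700 nM, the highest of the two numbers. Compound 2 `O=C(Nc1ccc(Cl)cc1)Nc1nc(Sc2c[nH]c3ccccc23)cc(N2CCCC2)n1` gives 7870 nM in this assay, and since the two values lie within the usual scatter of each other, nothing separates compound 1 from compound 2 on these numbers.

Compound 3 `O=C(Nc1ccccc1)Nc1nc(Sc2c[nH]c3ccccc23)cc(N2CCN(Cc3ccccc3)CC2)n1` has not yet been measured. It differs from compound 1 in a single place: phenyl in place of 4-chloro-2-methylphenyl on an amide-type nitrogen. Within the data shown here, no pair of measured compounds differs in this same way, so there is no precedent in the data for what the loss of the chlorine and the methyl group from the aryl urea does in this assay. The expectation for compound 3 therefore rests on compound 1, because its value of 11700 nM is the only anchor available. The step is expected to be a 1.4-fold higher number from compound 1 to compound 3 (0.14 log units; within the scatter), a modest move toward a higher number that may not clear the scatter. Compound 3 is thus estimated to give 16000 nM in this assay, with a range from 5000 nM to 50000 nM.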

Compound 3, half-maximal inhibitory concentration: 8160 nM
Compound 3: middle estimate off by 2.0-fold (0.29 log units), on the high side, and the stated range covers the measured number.
By their numbers in this assay, from the lowest: compounds 2, 3 and 1 (each within the scatter of the next).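

In this assay, putting phenyl in place of 4-chloro-2-methylphenyl on an amide-type nitrogen gives a 1.4-fold lower number from compound 1 to compound 3 (0.16 log units; within the scatter), so the step does not separate the two compounds. Within the data shown here, this is the first comparison in the set that isolates a single place, and it shows that, in the setting of compound 1, the chlorine and the methyl group can leave together without a change that clears the scatter of this assay. No supporting measurement bears on this result.

The pair removes both substituents at once, so it leaves open whether the chlorine or the methyl group alone, as in a 4-chlorophenyl or a 2-methylphenyl group at the same nitrogen, would read the same way, or whether their separate contributions are hidden within this single step. It also leaves open whether this position tolerates groups of a different kind, such as a carboxylic acid, an amine or a longer chain on the phenyl ring, and compound 2 cannot help here, as it differs from compound 1 and compound 3 in more than one place.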